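Swapping phenyl for quinolin-3-yl at the assay limit

The source may hold more compounds than are shown below. What is called first, only, known or untested is meant among the compounds shown, and "the series" means these compounds.

Of the compounds shown here, three sharing one core have been tested in a functional assay on NCI-H1993 cells (Homo sapiens) for inhibition, read by CCK-8 assay, with a stated time of 72 h (on this read-out lower numbers stand for stronger inhibition and higher numbers for weaker inhibition), and differ only in the aromatic group attached to that core. Compound 1 (`CC(c1cc(F)c2ncccc2c1)n1cnc2ncc(-c3cnn(C)c3)nc21`), carrying 1-methyl-1H-pyrazol-4-yl, gives > 10000 nM as a limit of the assay and not a number. Compound 2 (`CC(c1cc(F)c2ncccc2c1)n1cnc2ncc(-c3ccncc3)nc21`), carrying pyridin-4-yl, gives > 10000 nM as a limit too. Compound 3 (`CC(c1cc(F)c2ncccc2c1)n1cnc2ncc(-c3ccccc3)nc21`), carrying phenyl, also gives > 10000 nM as a limit. Compound 3 therefore has no exact position in the series and stands with the others.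

Compound 4 (`CC(c1cc(F)c2ncccc2c1)n1cnc2ncc(-c3cnc4ccccc4c3)nc21`) keeps the core and replaces phenyl with quinolin-3-yl (quinolin-3-yl in place of phenyl on an aromatic carbon) on the same aromatic carbon. Two measured swaps at this place bear on the change: a step that the two limits leave unreadable from compound 1 to compound 3 and a step that the two limits leave unreadable from compound 2 to compound 3 in turn. Neither has a size that can be read, so neither gives a direction. Among the compounds with values here, the only firm guide is the limit of > 10000 nM in this assay, at which 3 of the 3 values shown sit, for the three different groups tried so far. No step beyond the usual scatter is therefore expected, and the estimated change is a number no higher from compound 3 to compound 4 (the limit leaves the size open) in this assay for now. For compound 4 the expected value is 10000 nM with an estimated range from 3000 nM to 20000 nM and a good chance of another limit.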

Compound 4, half-maximal inhibitory concentration: > 10000 nM
Compound 4: a limit, no number (the forecaster's own chance of this, stated with the estimate: 75%); the middle value sits exactly at the limit.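

No step from compound 1, compound 2 or compound 3 to compound 4 can be read, because all four compounds sit at the same limit of the assay, which is not a number: the limit of > 10000 nM in this assay, at which 4 of the 4 values shown sit.

The compounds shown leave open how strongly any of them acts in this assay, and whether any group at this place on the shared core would give a measurable value.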